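The source may report more compounds than this note shows. Statements on the series, on what has been measured and on what is new or still open speak of the compounds shown alone.

In a functional assay on MCF7 cells (Homo sapiens) for cytotoxicity, read by MTT assay (a higher number here means a weaker inhibitor, a lower number a stronger inhibitor), the methyl ester compound 1 `COC(=O)C[C@H]1C[C@@H](O)[C@@H](C)[C@@H](c2ccc(C(C)C)cc2)N1` is reported as "not active" (no number reported), with no number given. Compound 2 `COC(=O)C[C@H]1C[C@@H](O)[C@@H](C)[C@@H](c2ccc(OC)cc2)N1` gives 10400 nM, and compound 3 `COC(=O)C[C@H]1C[C@H](O)[C@@H](C)[C@@H](c2ccc(OC)cc2)N1` gives 5100 nM. Compound 2 therefore holds the higher of the two numbers in this assay. The next compound, compound 4 `COC(=O)C[C@H]1C[C@@H](O)[C@@H](C)[C@@H](c2ccc(F)cc2)N1`, carries fluoro in place of methoxy on an aromatic carbon. Among the compounds with values here, the only measured step is a 2.0-fold lower number from compound 2 to compound 3 (0.31 log units; beyond the scatter), a modest one. It says little about this change because of the fact that compounds 2 and 3 differ only in the configuration as drawn. Within the data shown here, no measured step tests the aromatic substituent directly. Among the measured compounds shown here, compound 1, which has another group at that place, shows only that a change there can leave no number at all. With so little to go on, no clear direction is expected, and the expected change in this assay stays small, as a 1.2-fold higher number from compound 2 to compound 4 (0.06 log units; within the scatter). For compound 4 the estimated value is 12000 nM, with an expected range from 4000 nM to 36000 nM.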

Compound 4, half-maximal inhibitory concentration: 15600 nM
Estimate against measurement, compound 4: 1.3-fold (0.11 log units) below; measured number inside the range.
By their numbers in this assay, from the lowest: compound 3; then compounds 2 and 4 (each within the scatter of the next).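

With a number on both sides, the swap of methoxy for fluoro on this aromatic carbon gives a 1.5-fold higher number from compound 2 to compound 4 (0.18 log units; within the scatter) in this assay. Within the data shown here, this is the first direct reading at this position, and it shows that the two groups cannot be told apart here: the smaller fluoro, with no hydrogen-bond acceptor counted, leaves the cytotoxicity reading in the same range as methoxy, whereas compound 1, with its other group at that place, gave only "not active" (no number reported) as a result. Nothing measured here accounts for the step. As far as these compounds go, it remains open what an amine, a carboxylic acid or a longer chain on that aromatic carbon would do. From the compounds shown here alone, it is also open whether the step of a 2.0-fold lower number from compound 2 to compound 3 (0.31 log units; beyond the scatter) at the saturated ring carbon would recur with fluoro in place of methoxy.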